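Glycine Transporter Inhibitors: An Aryl Swap on the Saturated Ring

The compounds below may be only part of what the source reports. "The series", "measured", "known", "first", "only" and "open" are said of these compounds alone.

Two compounds have been measured so far in an assay on cells for inhibition of sodium- and chloride-dependent glycine transporter 1 (Homo sapiens); on this read-out lower numbers stand for an effect already at smaller amounts and higher numbers for an effect only at larger amounts of compound:
compound 1, `COc1cc(C(F)(F)F)cc(C(F)(F)F)c1C(=O)NC1(c2ccccc2)CCCN(Cc2ccccc2)C1`, with a value of 6700 nM;
compound 2, `COc1cc(C(F)(F)F)cc(SC)c1C(=O)NC1(c2ccc(C)cc2)CCCN(C)C1`, with a value of 230 nM.

Compound 2 gives the lower of the two numbers in this assay, and compound 1 stands well apart from it, at a gap beyond the usual scatter. The two compounds differ in several places at once, so the numbers alone say nothing about which of those changes matters.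

Compound 3, `COc1cc(C(F)(F)F)cc(SC)c1C(=O)NC1(c2ccc(F)cn2)CCCN(C)C1`, has not yet been measured. It differs from compound 2 in one place: 5-fluoropyridin-2-yl in place of 4-methylphenyl on a saturated ring carbon. Among the compounds with values here, no measured pair in this set shows what such a swap does in this assay, so there is no step to lean on. From compound 2 alone, a small step upward in number, not clearly beyond the scatter, is expected for a 1.7-fold higher number from compound 2 to compound 3 (0.24 log units; within the scatter). Compound 3 is therefore estimated at 400 nM, with a range from 120 nM to 1500 nM.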

Compound 3, half-maximal effective concentration: 180 nM
Compound 3: the middle estimate sits 2.2-fold (0.35 log units) above what was measured, within the range that was stated.
By their numbers in this assay, from the lowest: compounds 3 and 2 (each within the scatter of the next); then compound 1.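

In this assay, the first pair differing in one place gives a 1.3-fold lower number from compound 2 to compound 3 (0.11 log units; within the scatter) as the step for 5-fluoropyridin-2-yl in place of 4-methylphenyl, so at this saturated ring carbon, two ring bonds from the ring nitrogen, the two groups cannot be told apart on this read-out. The entering group has a hetero atom in its six-membered aromatic ring and a fluorine, neither of which 4-methylphenyl has, yet compound 2 and compound 3 stay within the scatter of each other, which shows that an aromatic ring of carbon only is not required at this position for a number of this size. Nothing measured here speaks to why the number holds across this change.

The compounds shown leave open whether this position would hold the number with a group of another kind in place of these aromatic rings, such as a cyclohexyl ring, a carboxylic acid or a longer alkyl chain. They also leave open whether the swap would read the same if an ethyl group took the place of the methyl group on the ring nitrogen.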